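The source may report more compounds than this note shows. Statements on the series, on what has been measured and on what is new or still open speak of the compounds shown alone.

Measured in a functional assay on PANC-1 cells (Homo sapiens) for inhibition, read by sulforhodamine B assay, with a stated time of 48 h; a higher number here means a weaker inhibitor of growth, a lower number a stronger inhibitor of growth:
- compound 1 `Cc1ccn2c(CN3CCCCC3)c(-c3ccccc3)nc2n1`: 20 nM
- compound 2 `c1ccc(-c2nc3ncccn3c2CN2CCCC2)cc1`: 60 nM

Among the compounds with values here, only these two compounds have values so far. Compound 2 holds the higher number, so it is the weaker inhibitor of growth of the pair, and its gap to compound 1 lies beyond the usual scatter. Within the data shown here, no pair of measured compounds differs in just one place, so no measured step can serve as a direct guide.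

The next compound, compound 3 `c1ccc(-c2nc3ncccn3c2CN2CCCCC2)cc1`, keeps the core of compound 2 and changes only the amine: piperidin-1-yl in place of pyrrolidin-1-yl on a saturated chain carbon bound to an aromatic carbon. The swap puts piperidin-1-yl in place of pyrrolidin-1-yl on a saturated chain carbon bound to an aromatic carbon.

Among the measured compounds shown here, the only hint comes from compound 1, which also bears piperidin-1-yl and gives 20 nM, although its core is not identical. A small move toward a lower number in this assay is therefore expected, of about the size of the scatter, and no change at all would not be surprising. The estimated change is a 1.7-fold lower number from compound 2 to compound 3 (0.23 log units; within the scatter). For compound 3 the expected value is 35 nM, with an estimated range from 12 nM to 100 nM.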

Compound 3, concentration for 50% growth inhibition: 1310 nM
Estimate against measurement, compound 3: 37-fold (1.57 log units) below; measured number outside the range, above it.
By their numbers in this assay, from the lowest: compound 1; then compound 2; then compound 3.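

In this assay, the amine on the saturated chain carbon bound to an aromatic carbon proves to be a sensitive point on this core: piperidin-1-yl in place of pyrrolidin-1-yl gives a 22-fold higher number from compound 2 to compound 3 (1.34 log units; beyond the scatter). The piperidin-1-yl group therefore does not bring a low number by itself, since with that group held fixed, hydrogen in place of methyl on an aromatic carbon gives a 66-fold higher number from compound 1 to compound 3 (1.82 log units; beyond the scatter), so a single methyl group also has a large effect in this series. Nothing available explains why either of these steps is so large.

As far as these compounds go, it remains open whether the swap from pyrrolidin-1-yl to piperidin-1-yl would have the same size with the methyl group present, and whether another group on that aromatic carbon, such as ethyl or chlorine, would act as methyl does. From the compounds shown here alone, how other amines on the chain carbon, such as morpholin-4-yl or an open-chain dimethylamino group, would compare with these two rings also remains open.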